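The source may report more compounds than this note shows. Statements on the series, on what has been measured and on what is new or still open speak of the compounds shown alone.

Measured so far:
- compound 1 `Fc1ccc(Nc2cc3[nH]c(Nc4cc(N5CCNCC5)ccn4)nc3cn2)cc1C(F)(F)F`: 73%
- compound 2 `C[C@@H]1CN(c2ccc(Nc3nc4cnc(Nc5ccc(F)c(C(F)(F)F)c5)cc4[nH]3)nc2)C[C@H](C)O1`: 19%
- compound 3 `Fc1ccc(Nc2cc3[nH]c(Nc4ccc(N5CCNCC5)cn4)nc3cn2)cc1F`: 73%

All three values come from an ADME assay on microsomes from liver (Rattus norvegicus) for metabolic stability, read by LC-MS, using NADPH, with a stated time of 60 min, tested at 0.1 uM; on this read-out lower numbers stand for a less stable compound and higher numbers for a more stable compound. Compound 1 stands level with compound 3, the two being within the scatter of each other, while compound 2 lies far lower, well beyond the scatter. Compound 1 and compound 3 both carry piperazin-1-yl, which compound 2 lacks, but three compounds are a thin base, and they also differ elsewhere.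

The next entry is compound 4 `C[C@@H]1CN(C(=O)c2ccnc(Nc3nc4cnc(Nc5ccc(F)c(C(F)(F)F)c5)cc4[nH]3)c2)C[C@H](C)N1`, which departs from compound 1 in one place: (3,5-dimethylpiperazin-1-yl)carbonyl in place of piperazin-1-yl on an aromatic carbon. In words, (3,5-dimethylpiperazin-1-yl)carbonyl stands in place of piperazin-1-yl on an aromatic carbon. Going by the values given here, the series holds no measured step between compounds that differ in one place, so the size of this step in this assay is a judgement and not a read-across. A moderate fall is expected, towards lower stability, leaving compound 4 nearer to compound 1 at 73% than to compound 2 at 19%. The estimated change is a number 15 percentage points lower from compound 1 to compound 4 (beyond the scatter), with wide uncertainty. For compound 4 the estimated value is 58%, with an expected range of 30% to 82%.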

Compound 4, percent of the compound remaining: 90%
Beside the measured number, compound 4's estimate is 32 percentage points below it; measured number above the stated range.
By their numbers in this assay, from the lowest: compound 2; then compounds 1 and 3 (each within the scatter of the next); then compound 4.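

In this assay, going by these compounds alone, (3,5-dimethylpiperazin-1-yl)carbonyl in place of piperazin-1-yl, on the aromatic carbon opposite the ring nitrogen, gives a number 17 percentage points higher from compound 1 to compound 4 (beyond the scatter), the first step that can be read at one place. At this position, the larger group, with 10 heavy atoms against 6, a carbonyl and 2 defined stereocentres, therefore comes with a higher number on this read-out rather than a loss. The step changes the carbonyl, the two methyl groups and the stereocentres together, so it cannot be assigned to any one of them, and no supporting data bear on why the number rises.

Open, going by these compounds, is how (piperazin-1-yl)carbonyl without the two methyl groups, or 3,5-dimethylpiperazin-1-yl joined directly without the carbonyl, would read at this place, as either would begin to separate the two parts of the change. Also open, on these data alone, is whether a different amide, such as morpholin-4-ylcarbonyl, would give a similar number, and whether the step would carry over to the other compounds.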